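From Chloro to Amino on a Limit Compound

The compounds below may be only part of what the source reports. "The series", "measured", "known", "first", "only" and "open" are said of these compounds alone.

Measured in a functional assay on the whole organism (Tail) for activation, with Mus musculus as the target, with a stated time of 1 min; on this read-out lower numbers stand for an effect already at smaller amounts and higher numbers for an effect only at larger amounts of compound:
- Compound 1 `O=C1NC(=O)N(/N=C/c2ccc(-c3ccc(Cl)c(Cl)c3)o2)C1O`: 34 mg/kg
- Compound 2 `O=C1NC(=O)N(/N=C/c2ccc(-c3ccc(Cl)cc3)o2)C1O`: > 1000 mg/kg (a limit, not a number)
- Compound 3 `O=C1CN(/N=C/c2ccc(-c3cccc(C(F)(F)F)c3)o2)C(=O)N1`: 184 mg/kg

Compound 2 gives only a limit and no number: the limit of > 1000 mg/kg in this assay, at which 1 of the 3 values shown sits. Compound 4 `Nc1ccc(-c2ccc(/C=N/N3C(=O)NC(=O)C3O)o2)cc1` has not yet been measured. It differs from compound 2 in one place, with amino in place of chloro on an aromatic carbon, para to a large group: amino in place of chloro on an aromatic carbon.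

Going by the values given here, one measured step bears on this change: an at least 29-fold higher number from compound 1 to compound 2 (1.46 log units; beyond the scatter). This large step lies beyond the scatter and shows that a single chloro can matter greatly in this assay. However, it concerns a different chloro on that ring and says nothing directly about amino, and no amino compound has been measured. Compound 3 carries no chloro and still gives 184 mg/kg, although its core is not the same.

A modest move towards a lower number therefore seems most likely, with a real chance of another limit. The expected change is an at least 2.5-fold lower number from compound 2 to compound 4 (0.39 log units; beyond the scatter). For compound 4 the estimate is 400 mg/kg, with an expected range from 80 mg/kg to 2000 mg/kg.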

Compound 4, dose for half-maximal effect: > 1000 mg/kg
Compound 4 gave a limit, no number; the forecaster's own chance of this, stated with the estimate: 45%; at least 2.5-fold (0.39 log units) between middle value and limit.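

Compound 2 and compound 4 both end at a limit rather than a number, so no step between them can be read: the limit of > 1000 mg/kg in this assay, at which 2 of the 4 values shown sit.

The compounds shown leave open whether amino in place of chloro on this aromatic carbon makes any difference to the dose needed for an effect.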